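The compounds below may be only part of what the source reports. "The series", "measured", "known", "first", "only" and "open" are said of these compounds alone.

Going by the values given here, compound 1 `Cc1oc(-c2c(Cl)cccc2Cl)nc1CN1CCC(C(=O)NCCCN2C[C@H](C)C[C@H](C)C2)CC1` is one of three compounds measured in an ADME assay on Huh7.5.1 cells (Homo sapiens) for cytotoxicity, read by ATP content, with a stated time of 48 h (on this read-out higher numbers stand for lower toxicity in this test and lower numbers for higher toxicity in this test), and compound 1 gives 13200 nM. This is the second highest of the three numbers. The nearest is compound 2 `Cc1ccccc1-c1nc(CN2CCC(C(=O)NCCCN3[C@H](C)CCC[C@@H]3C)CC2)c(C)o1`, which in this assay gives 21300 nM, a difference that lies within the scatter, so the two cannot be ordered. The furthest is compound 3 `Cc1ccccc1-c1nc(CN2CCC(C(=O)NCCCN3CCCC(CC(C)C)C3)CC2)c(C)o1`, which in this assay gives 4640 nM, a number beyond the scatter below that of compound 1.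

Among the compounds with values here, the one single-point step among the measured compounds is a 4.6-fold lower number from compound 2 to compound 3 (0.66 log units; beyond the scatter). That step concerns the group on the saturated chain carbon three bonds along the chain from the amide-type nitrogen; it says nothing about the aromatic group on the five-membered aromatic ring.

Compound 4 `CCc1ccccc1-c1nc(CN2CCC(C(=O)NCCCN3C[C@H](C)C[C@H](C)C3)CC2)c(C)o1` differs from compound 1 only there: 2-ethylphenyl in place of 2,6-dichlorophenyl on an aromatic carbon. The group that leaves, 2,6-dichlorophenyl, and the group that enters, 2-ethylphenyl, sit on an aromatic carbon next to the ring nitrogen and next to the ring oxygen. Within the data shown here, no measured pair changes this position, so there is no step to lean on, and the expectation for compound 4 is no change beyond the scatter, a step of a 1.0-fold lower number from compound 1 to compound 4 (0.01 log units; within the scatter). Compound 4 is therefore estimated at 13000 nM, with a range from 5000 nM to 32000 nM.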

Compound 4, half-maximal cytotoxic concentration: 9320 nM
Beside the measured number, compound 4's estimate is 1.4-fold (0.14 log units) above it; low and high end bracket the measured number.
By their numbers in this assay, from the lowest: compounds 3, 4, 1 and 2 (each within the scatter of the next, the first and the last beyond it).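

In this assay, going by these compounds alone, replacing 2,6-dichlorophenyl with 2-ethylphenyl on the aromatic carbon gives a 1.4-fold lower number from compound 1 to compound 4 (0.15 log units; within the scatter), the first measured step at this position. The two groups, which have the same number of heavy atoms and differ in that one carries two chlorine atoms and the other an ethyl group, therefore cannot be told apart in this test, whereas the earlier step on the saturated chain carbon lay beyond the scatter. No measurement shown here explains the result, so it stands as an observation about this one pair of compounds.

The compounds shown leave open whether a phenyl ring without any substituent, or one carrying a carboxylic acid or an amine, would give a number beyond the scatter from that of compound 1 at this position. They also leave open whether replacing 2,6-dichlorophenyl with 2-ethylphenyl would give a similarly small step in a compound that carries the group of compound 3 on the saturated chain carbon.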